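Working notes on a methyl-to-hydrogen step in the series

The source may hold more compounds than are shown below. What is called first, only, known or untested is meant among the compounds shown, and "the series" means these compounds.

The series is followed in a functional assay on HT-1080 cells (Homo sapiens) for cytotoxicity, read by MTT assay, with a stated time of 72 h; on this read-out lower numbers stand for stronger inhibition and higher numbers for weaker inhibition. Compound 1 `COc1ccc(CCC(=O)c2ccc(O)cc2)c(OC)c1` opens the set. In this assay compound 1 reaches only > 100000 nM, which is a limit of the assay and not a number. Compound 2 `O=C1c2ccc(O)cc2OC[C@H]1Cc1ccc(O)cc1` is the second member. In this assay compound 2 likewise stops at the limit > 100000 nM. Compound 3 `COc1ccc(CCC(=O)c2ccc(O)cc2)c(O)c1` is the third member. In this assay compound 3 again gives only the limit > 100000 nM. Compound 3 therefore stands at the same point as the other two, with no number of its own. For the measured compounds named here, the one step measured so far, a step that the two limits leave unreadable from compound 1 to compound 3, cannot be sized because the limit of > 100000 nM in this assay, at which 3 of the 3 values shown sit, holds both of its ends. Compound 4 `O=C(CCc1ccc(O)cc1O)c1ccc(O)cc1` differs from compound 3 by hydrogen in place of methyl on an oxygen on an aromatic ring. Going by the values given here, the only measured step that bears on this change is the one just named, and it gave no readable size; nothing among the three measured compounds points to a gain that would bring compound 4 inside the measurable range. The expected step that the limit leaves unreadable from compound 3 to compound 4 is therefore none beyond the scatter, most likely ending at the limit once more. Compound 4 is estimated at 150000 nM, in a range from 40000 nM to 600000 nM.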

Compound 4, half-maximal inhibitory concentration: > 100000 nM
Compound 4: only a limit was reported; the forecaster's own chance of this, stated with the estimate: 80%; the middle value does not contradict the limit.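

In this assay compound 4 gives > 100000 nM, which is a limit of the assay and not a number. No size can be read for the step between compound 3 and compound 4, because both of its ends rest on the same limit: the limit of > 100000 nM in this assay, at which 4 of the 4 values shown sit. The compounds shown leave open whether methoxy to hydroxy changes cytotoxicity at all.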